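This account rests on a few compounds, and the source may have more. Where it says the series, first, only, none or still open, it means among the compounds named here.

Measured so far in an ADME assay on A549 cells (Homo sapiens) for cytotoxicity, read by resazurin assay, with a stated time of 48 h; a lower number here means that less compound is tolerated, a higher number that more compound is tolerated:
compound 1 `O=C(Nc1ccc(NCc2cccc(C(F)(F)F)c2)cc1Cl)c1cc(Cl)ccc1O` gives 13300 nM
compound 2 `O=C(Nc1ccc(NCc2cc(F)cc(C(F)(F)F)c2)cc1Cl)c1cc(Cl)ccc1O` gives 30900 nM
compound 3 `O=C(Nc1ccc(NC2CCCC2)cc1)c1cc(Cl)ccc1O` gives 10000 nM

Compound 1 and compound 2 share one core and differ by fluoro in place of hydrogen on an aromatic carbon; this change moved the readout by a 2.3-fold higher number from compound 1 to compound 2 (0.37 log units; beyond the scatter). Compound 3 carries a different core and a cyclopentylamino group; the difference between the two cores is not broken down here. Compound 3 and compound 1 lie within the scatter of each other, while compound 2 sits beyond the scatter from compound 3.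

Compound 4 `O=C(Nc1ccc(NC2CCCC2)cc1F)c1cc(Cl)ccc1O` is not yet measured. It differs from compound 3 by fluoro in place of hydrogen on an aromatic carbon. This is the same kind of change as that from compound 1 to compound 2, but not the same: there the fluoro entered meta to a large group and meta to a trifluoromethyl group, whereas here it enters ortho to a large group and meta to a cyclopentylamino group, and on the other core.

Within the data shown here, for compound 4 in this assay a modest step upward is expected, a 1.5-fold higher number from compound 3 to compound 4 (0.18 log units; within the scatter), resting on the direction and size of the only measured instance, a 2.3-fold higher number from compound 1 to compound 2 (0.37 log units; beyond the scatter), tempered because the place and core differ and because compound 3 itself stands at 10000 nM. The estimate for compound 4 is 15000 nM, expected to fall between 6000 nM and 40000 nM.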

Compound 4, half-maximal cytotoxic concentration: 51000 nM
Estimate against measurement, compound 4: 3.4-fold (0.53 log units) below; measured number above the stated range.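

In this assay, fluoro in place of hydrogen on an aromatic carbon gives a 5.1-fold higher number from compound 3 to compound 4 (0.71 log units; beyond the scatter), the same direction as on the core of compound 1, and the two steps cannot be told apart in size: the same change on two cores in this assay, a 2.3-fold higher number (0.37 log units; beyond the scatter) from compound 1 to compound 2 and a 5.1-fold higher number (0.71 log units; beyond the scatter) from compound 3 to compound 4, 2.2-fold (0.34 log units) apart, within the scatter of two such steps

On these two pairs, then, the change carries over from one core to the other in direction, with more compound tolerated after it each time, and nothing shows that the size of the step depends on the core. Among these compounds, this does not make a rule for the series: there are only two pairs, the fluoro enters at a different place in each, and core and place therefore cannot be separated, so neither the agreement in direction nor the closeness in size can be assigned to either one.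

Going by these compounds, it remains open whether the rise belongs to fluoro itself or would also appear with a methyl group or a nitrile on the same aromatic carbon. Also open, on these data alone, is whether the step would hold on a core carrying a carboxylic acid or a basic amine in place of the cyclopentylamino group, and whether it would hold with fluoro at other places on the ring.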